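A few compounds are considered here, and "the series" means these few. Any claim that something is new, unique, unknown or untested is made for them only; others in the source may bear on it.

Measured so far in a functional assay on DU-145 cells (Homo sapiens) for cytotoxicity, read by CCK-8 assay; a higher number here means a weaker inhibitor, a lower number a stronger inhibitor:
Compound 1, `Oc1ccc(-c2cc(-c3cccs3)cc(-c3ccccc3O)n2)cc1`: compound 1 gives > 50000 nM, which is a limit of the method rather than a number.
Compound 2, `Oc1ccc(-c2cc(-c3ccccn3)cc(-c3ccccc3O)n2)cc1`: compound 2 gives 25400 nM.
Compound 3, `Oc1cccc(-c2cc(-c3cccnc3)cc(-c3ccccc3O)n2)c1`: compound 3 gives 5580 nM.

Compound 3 has the lowest of the two numbers shown; its nearest neighbour, compound 2, sits higher by a step that lies beyond the usual scatter, while the third value is only a limit. For the measured compounds named here, the single measured step, an at least 1.9-fold lower number from compound 1 to compound 2 (0.29 log units; that floor lies within the scatter), concerns the third aromatic ring, not the hydroxyphenyl group, and its floor lies within the scatter.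

Compound 4, `Oc1ccc(-c2cc(-c3cccnc3)cc(-c3ccccc3O)n2)cc1`, differs from compound 3 in one place: 4-hydroxyphenyl in place of 3-hydroxyphenyl on an aromatic carbon. Going by the values given here, no measured step addresses this change, since compound 2 carries both the 4-hydroxyphenyl and a different third ring, so what the two values show cannot be separated. With the higher value of compound 2 as the only hint, a modest rise from compound 3 is expected, of the size a 1.8-fold higher number from compound 3 to compound 4 (0.25 log units; within the scatter), close to the edge of the scatter. The estimate for compound 4 in this assay is 10000 nM, with a range from 3000 nM to 35000 nM.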

Compound 4, half-maximal inhibitory concentration: > 50000 nM
Compound 4 ended at the assay's limit (the forecaster's own chance of this, stated with the estimate: 10%); middle value at least 5.0-fold (0.69 log units) from the limit.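

In this assay, compound 3 and compound 4 differ in one place only, so the position of the hydroxyl on this ring can now be judged apart from the third ring: 4-hydroxyphenyl in place of 3-hydroxyphenyl, on the aromatic carbon next to the ring nitrogen, gives an at least 8.9-fold higher number from compound 3 to compound 4 (0.95 log units; beyond the scatter). With the 4-hydroxyphenyl group kept, pyridin-3-yl in place of pyridin-2-yl gives an at least 1.9-fold higher number from compound 2 to compound 4 (0.29 log units; that floor lies within the scatter), a floor that does not by itself show a real difference, and the step between compound 1 and compound 4 cannot be read. Compound 4 gives > 50000 nM, a limit of the assay and not a number, so only a floor is known for the size of the loss on moving the hydroxyl: the limit of > 50000 nM in this assay, at which 2 of the 4 values shown sit.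

On these data alone, whether the same move of the hydroxyl gives a similar step when the third ring is pyridin-2-yl or thiophen-2-yl stays open. The compounds shown also leave open what a methoxy group or an amine in place of that hydroxyl would do, and whether the 2-hydroxyphenyl group is needed at all.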